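This account rests on a few compounds, and the source may have more. Where it says the series, first, only, none or still open, it means among the compounds named here.

Compound 1 `Cc1ccc(-c2c(C)c(-c3ccccc3)c(C(OC(C)(C)C)C(=O)O)c(C)c2NS(C)(=O)=O)cc1C` was tested in an ADME assay on MT4 cells (Homo sapiens) for cytotoxicity, read by MTT assay, with a stated time of 4 days; on this read-out lower numbers stand for higher toxicity in this test and higher numbers for lower toxicity in this test; for compound 1 the result is a limit of the assay, > 50000 nM, not a number. Compound 2 `Cc1ccc(-c2c(C)c(-c3ccc(C)c(C)c3)c(C(OC(C)(C)C)C(=O)O)c(C)c2NC(=O)c2ccccc2)cc1C` gives 9100 nM in this assay, the only number shown. The other result, that of compound 1, is a limit (the limit of > 50000 nM in this assay, at which 1 of the 2 values shown sits). Compound 3 `Cc1ccc(-c2c(C)c(-c3ccc(C)c(C)c3)c(C(OC(C)(C)C)C(=O)O)c(C)c2NCc2ccccc2)cc1C` differs from compound 2 in one place: benzyl in place of benzoyl on a nitrogen on an aromatic ring. No step between measured compounds is shown, so the size of this change is unknown. The expected step is a 1.3-fold lower number from compound 2 to compound 3 (0.11 log units; within the scatter), no larger than the scatter. In this assay compound 3 is estimated at 7000 nM, between 2000 nM and 30000 nM.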

Compound 3, half-maximal cytotoxic concentration: 4000 nM
Compound 3: middle estimate off by 1.8-fold (0.24 log units), on the high side; low and high end bracket the measured number.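

Putting benzyl in place of benzoyl on this nitrogen, which removes the carbonyl, gives a 2.3-fold lower number from compound 2 to compound 3 (0.36 log units; beyond the scatter) in this assay. The group on this nitrogen therefore does change the read-out, and this change moves it modestly towards higher toxicity in this test. Nothing shown here gives a cause for this step. Still open, as far as these compounds go, is how a free amine or a longer alkyl chain on the same nitrogen would read, and whether the step from benzoyl to benzyl holds on a different core.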